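The source may report more compounds than this note shows. Statements on the series, on what has been measured and on what is new or still open speak of the compounds shown alone.

Compound 2 `O=S(=O)(Nc1ccccn1)c1ccc(Nc2nncc3ccccc23)cc1` gives 86 nM in a functional assay on HL-60 cells (Homo sapiens) for antiproliferative activity, read by sulforhodamine B assay, with a stated time of 72 h (on this read-out lower numbers stand for stronger inhibition and higher numbers for weaker inhibition), and stands at the top of the three numbers in hand, though its gap to compound 1 is within the scatter. Going by the values given here, compound 1 `Cc1cc(NS(=O)(=O)c2ccc(Nc3nncc4ccccc34)cc2)no1` gives 68 nM, and the step of a 1.3-fold higher number from compound 1 to compound 2 (0.10 log units; within the scatter) is the only single-point comparison measured. Compound 3 `C(=C/c1ccccc1)\C(=N\Nc1nncc2ccccc12)c1ccccc1` gives 4.7 nM, a far lower number, but shares no single-point change with compound 2. Compound 4 `Cc1cc(C)nc(NS(=O)(=O)c2ccc(Nc3nncc4ccccc34)cc2)n1` carries the change (4,6-dimethylpyrimidin-2-yl in place of pyridin-2-yl on a sulfonamide nitrogen). Among the compounds with values here, the one step that bears on it, a 1.3-fold higher number from compound 1 to compound 2 (0.10 log units; within the scatter), also swapped the ring on the sulfonamide nitrogen and stayed within the scatter, so for compound 4 no move beyond the scatter is expected in this assay. The expected step is a 1.0-fold higher number from compound 2 to compound 4 (0.02 log units; within the scatter). Compound 4 is expected at 90 nM, in the range 45 nM to 180 nM.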

Compound 4, half-maximal inhibitory concentration: 9.5 nM
Compound 4: middle estimate off by 9.5-fold (0.98 log units), on the high side; measured number outside the range, below it.
By their numbers in this assay, from the lowest: compound 3; then compound 4; then compounds 1 and 2 (each within the scatter of the next).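

The ring on the sulfonamide nitrogen is not a neutral position in this assay: 4,6-dimethylpyrimidin-2-yl moves the number beyond the scatter against pyridin-2-yl (a 9.1-fold lower number from compound 2 to compound 4 (0.96 log units; beyond the scatter)) and against 5-methyl-1,2-oxazol-3-yl (a 7.2-fold lower number from compound 1 to compound 4 (0.85 log units; beyond the scatter)). The earlier swap between those two rings showed no such move, so ring identity here can matter. Nothing measured here accounts for the step.

As far as these compounds go, the step changes ring nitrogens and methyl groups together, and which of them carries it stays open. An unsubstituted pyrimidin-2-yl or a 4,6-dimethoxypyrimidin-2-yl would be the next readings of interest at this position.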